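A few compounds are considered here, and "the series" means these few. Any claim that something is new, unique, unknown or untested is made for them only; others in the source may bear on it.

In a functional assay on SiHa cells (Homo sapiens) for inhibition, read by sulforhodamine B assay (on this read-out higher numbers stand for weaker inhibition of growth and lower numbers for stronger inhibition of growth), compound 1 `Cc1ccc2[nH]c(-c3ccc(-c4ccc(-c5cccc(Cl)c5)cc4)cc3)nc2c1` gives 3600 nM and compound 2 `Cc1ccc2[nH]c(-c3ccc(-c4ccc(-c5ccc(C(F)(F)F)cc5)cc4)cc3)nc2c1` gives 33200 nM as the higher of the two numbers. Compound 3 `Cc1ccc2[nH]c(-c3ccc(-c4ccc(-c5ccc(O)cc5)cc4)cc3)nc2c1` differs from compound 2 only by hydroxy in place of trifluoromethyl on an aromatic carbon. Among the measured compounds shown here, the one measured step at this end of the molecule is modest but beyond the scatter (a 9.2-fold higher number from compound 1 to compound 2 (0.96 log units; beyond the scatter)). On that single step, a change of similar size toward a lower number is expected in this assay and the expected step is (a 5.5-fold lower number from compound 2 to compound 3 (0.74 log units; beyond the scatter)). The estimate for compound 3 is 6000 nM (expected range 1500 nM to 25000 nM).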

Compound 3, concentration for 50% growth inhibition: 33500 nM
Compound 3: middle estimate off by 5.6-fold (0.75 log units), on the low side; the whole stated range lies below it.
By their numbers in this assay, from the lowest: compound 1; then compounds 2 and 3 (each within the scatter of the next).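

In this assay, hydroxy in place of trifluoromethyl gives a 1.0-fold higher number from compound 2 to compound 3 (0.00 log units; within the scatter), so at this place two groups that differ in size and in hydrogen-bond donors read alike. The 3-chlorophenyl compound still stands apart, with a 9.3-fold higher number from compound 1 to compound 3 (0.97 log units; beyond the scatter), so its lower number is not a contrast with 4-(trifluoromethyl)phenyl alone. Nothing at hand explains these results.

As far as these compounds go, whether an amine or a carboxylic acid on the same aromatic carbon would read like compound 2 and compound 3 stays open. Also open, from the compounds shown here alone, is whether the lower number of compound 1 goes with the chlorine itself or with where it sits on the ring.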